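The source may report more compounds than this note shows. Statements on the series, on what has been measured and on what is new or still open speak of the compounds shown alone.

In a functional assay on HCT-116 cells (Homo sapiens) for antiproliferative activity, read by MTT assay, with a stated time of 72 h (on this read-out lower numbers stand for stronger inhibition and higher numbers for weaker inhibition), compound 2 `Cc1cc(S(=O)(=O)/N=C(\N)N/N=C/C#Cc2ccccc2)c(SCc2ccccc2C(F)(F)F)cc1Cl` gives 18000 nM, the second highest of three numbers; compound 1 `C/C(C#Cc1ccccc1)=N\N/C(N)=N/S(=O)(=O)c1cc(C)c(Cl)cc1SCc1ccc(C)cc1` gives 13000 nM and compound 3 `C/C(C#Cc1ccccc1)=N\N/C(N)=N/S(=O)(=O)c1cc(C)c(Cl)cc1SCc1ccccc1C(F)(F)F` gives 23000 nM, and both lie within the scatter of compound 2. Compound 4 `Cc1cc(S(=O)(=O)/N=C(\N)N/N=C/C#Cc2ccccc2)c(SCc2cccc3ccccc23)cc1Cl` differs from compound 2 by naphthalen-1-yl in place of 2-(trifluoromethyl)phenyl on a saturated chain carbon bound to a sulfur. Among the compounds with values here, two measured steps bear on this. Swapping the group on that same carbon gave a 1.8-fold higher number from compound 1 to compound 3 (0.25 log units; within the scatter), and altering the group on the amine nitrogen gave a 1.3-fold higher number from compound 2 to compound 3 (0.11 log units; within the scatter). Neither step left the scatter, so no shift beyond the scatter is expected for the step to compound 4, that is no change at the digits printed from compound 2 to compound 4 (within the scatter). Compound 4 is therefore estimated at 18000 nM, in a range from 8000 nM to 40000 nM.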

Compound 4, half-maximal inhibitory concentration: 10000 nM
For compound 4 the middle estimate is 1.8-fold (0.26 log units) above the measured one; the measured number falls inside the stated range.
By their numbers in this assay, from the lowest: compounds 4, 1, 2 and 3 (each within the scatter of the next, the first and the last beyond it).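

In this assay, naphthalen-1-yl in place of 2-(trifluoromethyl)phenyl on a saturated chain carbon bound to a sulfur gives a 1.8-fold lower number from compound 2 to compound 4 (0.26 log units; within the scatter). This carbon therefore accepts a second six-membered aromatic ring and the loss of all three fluorines, at an unchanged heavy-atom count, with no step beyond the scatter. Nothing measured here offers a reason for this result. Still open, going by these compounds, is whether an amine or a carboxylic acid on the ring, or a plain butyl chain in place of the ring, would leave the scatter.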